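Adding a Trifluoromethyl Group: Expected Effect on Receptor Binding

A few compounds are considered here, and "the series" means these few. Any claim that something is new, unique, unknown or untested is made for them only; others in the source may bear on it.

Three compounds share one core and were measured in an assay on CHO-K1 cells for displacement of a labelled ligand from prostaglandin E2 receptor EP1 subtype (Homo sapiens); on this read-out higher numbers stand for weaker inhibition and lower numbers for stronger inhibition:

Compound 1, `Cc1cc(C(=O)O)nn1Cc1cc(Br)ccc1OCc1ccccc1`: 6.46 nM
Compound 2, `O=C(O)c1ccn(Cc2cc(Br)ccc2OCc2ccccc2)n1`: 9.77 nM
Compound 3, `Cc1cc(C(=O)O)nn1Cc1cc(Br)ccc1OCc1ccc(F)cc1`: 7.41 nM

Compound 1 gives the lowest of the three numbers, but the gaps to compound 3 and to compound 2 both fall within the scatter of repeated measurements, so the three compounds cannot be told apart on these data. The step of a 1.5-fold higher number from compound 1 to compound 2 (0.18 log units; within the scatter) removes the methyl from the core, and the step of a 1.1-fold higher number from compound 1 to compound 3 (0.06 log units; within the scatter) adds a fluoro to the benzyl ring; neither moved the number beyond the scatter.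

Compound 4, `Cc1cc(C(=O)O)nn1Cc1cc(Br)ccc1OCc1cccc(C(F)(F)F)c1`, has not been measured. It differs from compound 1 in one place: trifluoromethyl in place of hydrogen on an aromatic carbon. The entering group sits on an aromatic carbon of a six-membered aromatic ring of carbon only, meta to a large group. Among the compounds with values here, the only step that bears on this change is the one from compound 1 to compound 3, since it also places a small group on that same benzyl ring, and it stayed within the scatter. Trifluoromethyl is a larger group than fluoro, so some uncertainty remains, yet nothing measured here points in either direction.

For compound 4 the expected step is a 1.2-fold higher number from compound 1 to compound 4 (0.09 log units; within the scatter), and the estimated value is 8 nM, with a likely range from 3 nM to 25 nM.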

Compound 4, half-maximal inhibitory concentration: 309 nM
Compound 4: middle estimate off by 39-fold (1.59 log units), on the low side, and the stated range ends below it.
By their numbers in this assay, from the lowest: compounds 1, 3 and 2 (each within the scatter of the next); then compound 4.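

In this assay, the step of a 48-fold higher number from compound 1 to compound 4 (1.68 log units; beyond the scatter) shows that this ring does not accept every group: trifluoromethyl on an aromatic carbon of the six-membered aromatic ring of carbon only, meta to a large group, weakens inhibition by a wide margin. The earlier step with fluoro on the same ring, a 1.1-fold higher number from compound 1 to compound 3 (0.06 log units; within the scatter), gave no hint of this, so a ring that had looked open to change is now known to respond strongly to at least one group. Nothing measured here explains why the number rises so far.

The compounds shown leave open whether the loss belongs to trifluoromethyl itself or would appear with other groups at this carbon, such as a methyl, a chlorine, a methoxy group, a nitrile or an amine, and a series of these would show how far the effect follows the entering group. They also leave open whether trifluoromethyl would cost as much on the core of compound 2, which lacks the methyl of compound 1.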